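Notes on the step from compound 2 to compound 3

The source may hold more compounds than are shown below. What is called first, only, known or untested is meant among the compounds shown, and "the series" means these compounds.

Compound 2 `COc1cc(-c2nc(-c3ccccc3)[nH]c2-c2ccnc(NCCCNS(=O)(=O)c3cccc(F)c3)n2)ccc1F` holds the lowest of the two measured numbers: in a functional assay on LOX IMVI cells (Homo sapiens) for cytotoxicity, read by MTT assay, with a stated time of 24 h (on this read-out lower numbers stand for stronger inhibition and higher numbers for weaker inhibition), compound 2 gives 900 nM, whereas compound 1 `COc1cc(-c2nc(-c3ccccc3)[nH]c2-c2ccnc(NCCCNS(=O)(=O)c3ccccc3)n2)ccc1F` gives 4520 nM. Among the measured compounds shown here, the only recorded step is a 5.0-fold lower number from compound 1 to compound 2 (0.70 log units; beyond the scatter), which concerns a different part of the shared core. Compound 3 `O=S(=O)(NCCCNc1nccc(-c2[nH]c(-c3ccccc3)nc2-c2ccc(Cl)c(O)c2)n1)c1cccc(F)c1` differs from compound 2 by 4-chloro-3-hydroxyphenyl in place of 4-fluoro-3-methoxyphenyl on an aromatic carbon. For the measured compounds named here, no measured step touches this position on the five-membered aromatic ring with 2 nitrogen, so the known step gives no guide to direction or size. For compound 3 the expected outcome is no step beyond the scatter, a 1.1-fold higher number from compound 2 to compound 3 (0.05 log units; within the scatter), with an estimated value of 1000 nM and a range from 300 nM to 3500 nM.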

Compound 3, half-maximal inhibitory concentration: 33600 nM
Beside the measured number, compound 3's estimate is 34-fold (1.53 log units) below it; measured number outside the range, above it.
By their numbers in this assay, from the lowest: compound 2; then compound 1; then compound 3.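

This position on the five-membered aromatic ring with 2 nitrogen is sensitive in this assay: 4-chloro-3-hydroxyphenyl in place of 4-fluoro-3-methoxyphenyl gives a 37-fold higher number from compound 2 to compound 3 (1.57 log units; beyond the scatter), a large step towards weaker inhibition. The change alters both the halogen and the oxygen substituent, so the step cannot be assigned to either alone. Nothing available bears on its cause.

The compounds shown leave open which of the two alterations carries the step. They also leave open whether 4-chloro-3-methoxyphenyl or 4-fluoro-3-hydroxyphenyl at this place would keep the lower number.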